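A few compounds are considered here, and "the series" means these few. Any claim that something is new, unique, unknown or untested is made for them only; others in the source may bear on it.

In an ADME assay on T29 cells (Homo sapiens) for cytotoxicity, read by sulforhodamine B assay, with a stated time of 3 days (a higher number here means a weaker inhibitor, a lower number a stronger inhibitor), compound 1 (`O=Cc1cn(Cc2ccc(Cl)cc2)c2ccc(F)cc12`) gives > 31600 nM, which is a limit of the assay. Compound 2 (`O=Cc1cn(Cc2ccc(Cl)cc2)c2cc(F)ccc12`) gives > 31600 nM, also a limit and not a number. Compound 2 thus stands at the limit of > 31600 nM in this assay, at which 2 of the 2 values shown sit. Compound 3 (`O=Cc1cn(Cc2ccc(Cl)cc2)c2cc(Br)ccc12`) differs from it in one place: bromo in place of fluoro on an aromatic carbon. For the measured compounds named here, no measured step shows what such an exchange does. In this assay, only a small move toward stronger inhibition is expected, if any. The estimated change is an at least 1.0-fold lower number from compound 2 to compound 3 (0.02 log units; that floor lies within the scatter). Compound 3 is expected at 30000 nM, within an estimated range of 10000 nM to 60000 nM.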

Compound 3, half-maximal inhibitory concentration: 21000 nM
Estimate against measurement, compound 3: 1.4-fold (0.15 log units) above; the range from low to high includes it.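

In this assay, for the compounds shown here, compound 3 gives 21000 nM, the only value shown that is a number and not a limit. Compound 2 stands at a limit of the assay: the limit of > 31600 nM in this assay, at which 2 of the 3 values shown sit. The exchange at this position, on an aromatic carbon meta to a fused ring and para to a fused ring, can thus be read only as a floor: an at least 1.5-fold lower number from compound 2 to compound 3 (0.17 log units; that floor lies within the scatter).

On these data alone, whether the true difference lies beyond the scatter remains open. So does what an amine or a methoxy group would do at this position.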